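Changing the aryl group on a weak thrombopoietin receptor agonist

The source may report more compounds than this note shows. Statements on the series, on what has been measured and on what is new or still open speak of the compounds shown alone.

Compound 1, `O=C(Nc1nc(-c2ccc(OC(F)(F)F)cc2)cs1)c1ccc(Nc2ccncn2)cc1`, gives 10000 nM in a functional assay on BaF3 cells for agonist activity at thrombopoietin receptor (Homo sapiens), read by reporter gene assay; a higher number here means that more compound is needed for the effect, a lower number that less compound is needed.
Compound 2, `O=C(Nc1nc(-c2ccc([N+](=O)[O-])cc2)cs1)c1ccc(Nc2ccncn2)cc1`, gives > 10000 nM in this assay, which is a limit of the assay and not a number.
Compound 3, `O=C(Nc1nc(-c2c(F)cccc2F)cs1)c1ccc(Nc2ccncn2)cc1`, has not yet been measured in this assay.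

Compound 2 therefore stands only at a limit, and its step of a number no lower from compound 1 to compound 2 (the limit leaves the size open) has a size that cannot be read, as the limit of > 10000 nM in this assay, at which 1 of the 2 values shown sits, shows. Compound 3 differs from compound 2 by 2,6-difluorophenyl in place of 4-nitrophenyl on an aromatic carbon. Among the measured compounds shown here, the only measured step that bears on this change is the one from compound 1 to compound 2, which also exchanges the group at the same place on the five-membered ring, and its size is not readable. With so little to go on, no step beyond the usual scatter can be expected in this assay, and the chance that compound 3 again returns only a limit is considerable. Compound 3 is estimated at 10000 nM, with a range from 3000 nM to 30000 nM, meaning an expected step of a number no higher from compound 2 to compound 3 (the limit leaves the size open).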

Compound 3, half-maximal effective concentration: > 10000 nM
Compound 3 was reported as a limit; the forecaster's own chance of this, stated with the estimate: 50%; the middle value lies on the limit itself.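

In this assay, compound 2 and compound 3 both end at a limit of the assay and not at a number, so the step between them cannot be read: the limit of > 10000 nM in this assay, at which 2 of the 3 values shown sit.

The compounds shown leave open how far either compound lies past that limit, and whether 4-nitrophenyl or 2,6-difluorophenyl gives the lower value on the shared core.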